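This account rests on a few compounds, and the source may have more. Where it says the series, first, only, none or still open, it means among the compounds named here.

Measured compounds:
- compound 1, `CCCC(Oc1ccc(-n2cc(C(=O)N(C)C)cn2)cc1)c1ccc(C(=O)NCCC(=O)O)cc1`, with 6500 nM in an assay on cells for displacement of a labelled ligand from Glucagon receptor (Homo sapiens), in the presence of a further agent that is not named here; on this read-out higher numbers stand for weaker inhibition and lower numbers for stronger inhibition
- compound 2, `CC(C)CC(Oc1ccc(-n2cc(C(F)(F)F)cn2)cc1)c1ccc(C(=O)NCCC(=O)O)cc1`, with 549 nM in this assay

Compound 2 stands at the lowest number of the two, and the gap to compound 1 is beyond the scatter of repeated measurements, so compound 2 is the stronger inhibitor of the pair. Compound 1 and compound 2 differ in two places at once, in the chain and in the group on the five-membered ring, so the two numbers alone do not tell which of the two changes matters.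

Compound 3, `CCCC(Oc1ccc(-n2cc(C(F)(F)F)cn2)cc1)c1ccc(C(=O)NCCC(=O)O)cc1`, has not yet been measured in this assay. It keeps the trifluoromethyl group of compound 2 and differs from compound 2 only in the chain: hydrogen in place of methyl on a saturated chain carbon bound to two saturated chain carbons, so the isobutyl of compound 2 becomes the propyl of compound 3. Nothing measured here isolates this single change, so the expected step is a guess. The step is estimated as a small loss, about a 2.2-fold higher number from compound 2 to compound 3 (0.34 log units; beyond the scatter). On that basis compound 3 is estimated at 1200 nM, within a range from 400 nM to 4000 nM.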

Compound 3, inhibition constant: 890 nM
For compound 3 the middle estimate is 1.3-fold (0.13 log units) above the measured one, within the range that was stated.
By their numbers in this assay, from the lowest: compounds 2 and 3 (each within the scatter of the next); then compound 1.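

In this assay, hydrogen in place of methyl on a saturated chain carbon bound to two saturated chain carbons gives a 1.6-fold higher number from compound 2 to compound 3 (0.21 log units; within the scatter), so the isobutyl and propyl chains cannot be told apart on this read-out. With the propyl chain the same on both sides, trifluoromethyl in place of dimethylcarbamoyl on an aromatic carbon gives a 7.3-fold lower number from compound 1 to compound 3 (0.86 log units; beyond the scatter), so the two changes that were tangled together in the first pair can now be read one at a time, and only the change on the aromatic carbon gives a step beyond the scatter. No supporting measurement is available to explain either step.

On these data alone, the two chains are close relatives, so it remains open whether this position would accept something quite different, such as a much longer hexyl chain or a chain ending in an amine. As far as these compounds go, it is also open how other groups on the same aromatic carbon, such as a nitrile or a carboxylic acid, would compare with trifluoromethyl and dimethylcarbamoyl.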